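Chromane ureas in rat aorta: halogen swap on the core

The compounds below may be only part of what the source reports. "The series", "measured", "known", "first", "only" and "open" are said of these compounds alone.

Measured so far:
compound 1, `Cc1ccccc1NC(=O)NC1CC(C)(C)Oc2ccc(Cl)cc21`, > 10000 nM
compound 2, `Cc1ccccc1NC(=O)NC1CC(C)(C)Oc2ccc(Br)cc21`, > 30000 nM
compound 3, `CC1(C)CC(NC(=O)Nc2cccc(Cl)c2)c2cc(Cl)ccc2O1`, > 30000 nM

In a functional assay (aorta) with Rattus norvegicus as the target (a higher number here means that more compound is needed for the effect, a lower number that less compound is needed), compound 1 gives > 10000 nM, which is a limit of the assay and not a number. In this assay compound 2 gives > 30000 nM, again a limit. Compound 3 gives > 30000 nM in this assay, also a limit. The change from compound 1 to compound 2 is bromo in place of chloro on an aromatic carbon, and the step that the two limits leave unreadable from compound 1 to compound 2 cannot be read because both values sit at limits: the limit of > 10000 nM in this assay, at which 1 of the 3 values shown sits, and (the limit of > 30000 nM in this assay, at which 2 of the 3 values shown sit). The cores of compound 1 and compound 3 differ as 3-chlorophenyl in place of 2-methylphenyl on an amide-type nitrogen, and the step that the two limits leave unreadable from compound 1 to compound 3 is equally unreadable.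

Compound 4, `CC1(C)CC(NC(=O)Nc2cccc(Cl)c2)c2cc(Br)ccc2O1`, has not been measured in this assay. It differs from compound 3 as bromo in place of chloro on an aromatic carbon, the same change as that from compound 1 to compound 2, made at the same place on the core. Since compound 1 and compound 2 both stay at limits in this assay, and compound 3 is itself at a limit there, the expected step that the limit leaves unreadable from compound 3 to compound 4 is estimated to leave compound 4 outside the measurable range as well. Compound 4 is thus expected to give about 40000 nM in this assay, most likely reported as a limit, with an estimated range from 10000 nM to 150000 nM.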

Compound 4, half-maximal effective concentration: > 30000 nM
Compound 4 gave a limit, no number; the forecaster's own chance of this, stated with the estimate: 85%; the middle value is on the limit's open side.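

In this assay compound 4 gives > 30000 nM as a limit of the assay and not a number. With compound 2, compound 3 and compound 4 all at limits, no new step can be read for compound 4 against either of the other two. The compounds shown leave open what size of step, if any, this assay would give for bromo in place of chloro or for 3-chlorophenyl in place of 2-methylphenyl.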